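The compounds below may be only part of what the source reports. "The series", "measured", "known", "first", "only" and "open" are said of these compounds alone.

Compound 1 `CC(C)(NC(=O)Nc1ccc(F)c(C(F)(F)F)c1)C(=O)O` is followed here in a physicochemical assay for solubility, read by nephelometry, measured as kinetic solubility, at pH 2, tested at 10 mg/mL (a higher number here means a more soluble compound, a lower number a less soluble compound), where compound 1 gives 25 ug/mL. Its nearest neighbour among the measured compounds is compound 3 `O=C(Nc1ccc(F)c(C(F)(F)F)c1)NC1(C(=O)O)CCC1`, which in this assay gives 50 ug/mL; the step of a 2.0-fold higher number from compound 1 to compound 3 (0.30 log units; within the scatter) leaves the two compounds inside the usual scatter of one another, so neither can be set apart from the other on these numbers. Compound 2 `CC(C)(NC(=O)Nc1ccccc1)C(=O)O` in this assay gives > 100 ug/mL, which is a limit of the assay rather than a number (the limit of > 100 ug/mL in this assay, at which 1 of the 3 values shown sits). Compound 4 `CC(C)(NC(=O)Nc1ccc(F)c(C(F)(F)F)c1)C(N)=O` differs from compound 1 in one place: amino in place of hydroxy on a carbonyl carbon. For the measured compounds named here, none of the measured steps touches this change; the only measured step, a 2.0-fold higher number from compound 1 to compound 3 (0.30 log units; within the scatter), alters the group on the amide-type nitrogen and not the carbonyl carbon, and it stays within the scatter. There is therefore no basis among these compounds for expecting a shift beyond the scatter in either direction in this assay. Compound 4 is accordingly expected to give about 22 ug/mL in this assay, within a range from 7 ug/mL to 70 ug/mL. The step of a 1.1-fold lower number from compound 1 to compound 4 (0.06 log units; within the scatter) is thus expected to be small.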

Compound 4, solubility: 50 ug/mL
The estimate for compound 4 lay 2.3-fold (0.36 log units) below the measured number; low and high end bracket the measured number.
By their numbers in this assay, from the lowest: compounds 1, 3 and 4 (each within the scatter of the next). At a limit, above all of these: compound 2.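

In this assay the carbonyl carbon now carries a measured change, and the step is a 2.0-fold higher number from compound 1 to compound 4 (0.30 log units; within the scatter): amino in place of hydroxy on a carbonyl carbon does not set the two compounds apart, so this reading does not depend on the carboxy group in this pair. The other step, no change at the digits printed from compound 3 to compound 4 (within the scatter), likewise leaves compound 4 inseparable from the cyclobutyl acid. No measurement shown here speaks to why the carbamoyl and carboxy compounds read alike.

As far as these compounds go, whether methoxy or methylamino in place of hydroxy on this carbonyl carbon would also stay inside the scatter remains open. Also open, from the compounds shown here alone, is whether amino in place of hydroxy would read the same way on compound 3 or on compound 2.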